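From 1H-imidazol-2-yl to 2,5-dihydroxyphenyl on the shared core

The compounds below may be only part of what the source reports. "The series", "measured", "known", "first", "only" and "open" are said of these compounds alone.

For the measured compounds named here, in a functional assay on P388 cells (Mus musculus) for cytotoxicity (on this read-out lower numbers stand for stronger inhibition and higher numbers for weaker inhibition), compound 1 `Cc1cc(-c2c(F)cc3c(=O)c(Cc4ccc[nH]4)cn(C4CC4)c3c2F)cc(C)n1` gives 930 nM and compound 2 `Cc1cc(-c2c(F)cc3c(=O)c(Cc4ncc[nH]4)cn(C4CC4)c3c2F)cc(C)n1` gives 1100 nM as the only other number so far. These two values lie within the scatter of each other, so compound 2 stands level with compound 1 and no order can be drawn between them.

Compound 3 `Cc1cc(-c2c(F)cc3c(=O)c(Cc4cc(O)ccc4O)cn(C4CC4)c3c2F)cc(C)n1` shares the core and brings the change 2,5-dihydroxyphenyl in place of 1H-imidazol-2-yl on a saturated chain carbon bound to an aromatic carbon on a saturated chain carbon bound to an aromatic carbon, with 2,5-dihydroxyphenyl in place of 1H-imidazol-2-yl.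

Going by the values given here, the one measured step at that place is a 1.2-fold higher number from compound 1 to compound 2 (0.07 log units; within the scatter) and it put 1H-imidazol-2-yl in place of 1H-pyrrol-2-yl. Here a six-membered aromatic ring of carbon only enters instead, so that step is a weak guide and the data offer no direction. No step beyond the scatter is expected in this assay for now, though the uncertainty is wide. The estimated step is a 1.6-fold lower number from compound 2 to compound 3 (0.20 log units; within the scatter) as the central expectation. For compound 3 the estimated value is 700 nM with an expected range from 150 nM to 3000 nM for the measurement to test.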

Compound 3, half-maximal inhibitory concentration: 360 nM
For compound 3 the middle estimate is 1.9-fold (0.29 log units) above the measured one; the range from low to high includes it.
By their numbers in this assay, from the lowest: compound 3; then compounds 1 and 2 (each within the scatter of the next).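

In this assay, the group on a saturated chain carbon bound to an aromatic carbon now proves able to shift the read-out: 2,5-dihydroxyphenyl in place of 1H-imidazol-2-yl gives a 3.1-fold lower number from compound 2 to compound 3 (0.49 log units; beyond the scatter), whereas the earlier exchange of one five-membered aromatic ring for the other gave no readable step. The same holds against 1H-pyrrol-2-yl, with a 2.6-fold lower number from compound 1 to compound 3 (0.41 log units; beyond the scatter), so the modest gain appears against both five-membered rings and does not depend on which one serves as the reference. No measurement at hand accounts for this gain.

The change replaces a five-membered aromatic ring with hetero atoms by a six-membered aromatic ring of carbon only and also adds the two hydroxy groups, so these compounds cannot show which part of the change goes with the lower number. Plain phenyl and 3-hydroxyphenyl on the same chain carbon would separate those parts, while an amine or a carboxylic acid there would show whether the position accepts a group of a different kind.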